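Aryl swap on the alkyne: pyrazole to dimethylfuran

The source may report more compounds than this note shows. Statements on the series, on what has been measured and on what is new or still open speak of the compounds shown alone.

Compound 2 `CNC(=O)[C@@]12C[C@@H]1[C@@H](n1cnc3c(NC)nc(C#Cc4cnn(C)c4)nc31)[C@H](O)[C@@H]2O` gives 35% in an assay on CHO cells for displacement of a labelled ligand from adenosine receptor A1 (Homo sapiens), read by scintillation counting, with a stated time of 60 min, tested at 10 uM (a higher number here means more inhibition at the concentration tested (going by the name of the read-out), a lower number less inhibition), the higher of the two numbers measured; compound 1 `CNC(=O)[C@@]12C[C@@H]1[C@@H](n1cnc3c(NC)nc(C#Cc4ccccc4)nc31)[C@H](O)[C@@H]2O` gives 18%. Compound 3 `CNC(=O)[C@@]12C[C@@H]1[C@@H](n1cnc3c(NC)nc(C#Cc4cc(C)c(C)o4)nc31)[C@H](O)[C@@H]2O` differs from compound 2 by 4,5-dimethylfuran-2-yl in place of 1-methyl-1H-pyrazol-4-yl on a triple-bonded carbon. Within the data shown here, the one step that bears on this is a number 17 percentage points higher from compound 1 to compound 2 (beyond the scatter), also a change of the group on the triple-bonded carbon. That step shows such a change can shift the read-out beyond the scatter, but it gives no direction for the furan. The expected step is a number 8 percentage points lower from compound 2 to compound 3 (within the scatter), a modest fall. Compound 3 is estimated at 27%, between 8% and 48%.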

Compound 3, a percentage reported as inhibition, at one concentration (the size of the read-out at that concentration, not a potency): 15%
For compound 3 the middle estimate is 12 percentage points above the measured one; the measured number falls inside the stated range.
By their numbers in this assay, from the lowest: compounds 3 and 1 (each within the scatter of the next); then compound 2.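

In this assay the change from pyrazole to furan on the triple-bonded carbon gives a number 20 percentage points lower from compound 2 to compound 3 (beyond the scatter) and so the higher number of compound 2 is not shared by every five-membered aromatic ring here. Set against phenyl, 4,5-dimethylfuran-2-yl gives a number 3 percentage points lower from compound 1 to compound 3 (within the scatter) and so brings no separation from compound 1. Nothing measured here accounts for the gap between the two five-membered rings.

Open, from the compounds shown here alone, is whether an unsubstituted furan-2-yl reads like compound 3. Also open, going by these compounds, is how a pyrazole carrying an amine or a longer chain in place of its methyl reads in this assay at this position.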